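Methoxy addition on two cores of the series

A few compounds are considered here, and "the series" means these few. Any claim that something is new, unique, unknown or untested is made for them only; others in the source may bear on it.

Measured so far in an ADME assay on CCRF-CEM cells (Homo sapiens) for antiproliferative activity, with a stated time of 48 h; a higher number here means a weaker inhibitor, a lower number a stronger inhibitor:
- compound 1 `C=C(Br)C(=O)Nc1ccc(C(=O)/C=C/c2cccc(OC)c2)cc1` gives 1800 nM
- compound 2 `C=C(Br)C(=O)Nc1ccc(C(=O)/C=C/c2ccc(OC)c(OC)c2)cc1` gives 1600 nM
- compound 3 `Nc1ccc(/C=C/C(=O)c2ccccc2)cc1` gives 34000 nM

Compound 1 and compound 2 share a core and differ by methoxy in place of hydrogen on an aromatic carbon. The step of a 1.1-fold lower number from compound 1 to compound 2 (0.05 log units; within the scatter).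

Compound 3 gives the highest number of the three measured compounds. How its core differs from the core of compound 1 is not broken down here; only the two values themselves can be compared.

Compound 4 `COc1cccc(C(=O)/C=C/c2ccc(N)cc2)c1` is not yet measured. It differs from compound 3 by methoxy in place of hydrogen on an aromatic carbon. This is the same kind of change as that from compound 1 to compound 2, but not the same: in the measured pair the entering methoxy sits ortho to a methoxy group and para to a large group, whereas in compound 4 it sits meta to a large group.

For the measured compounds named here, the only measured step of this kind, a 1.1-fold lower number from compound 1 to compound 2 (0.05 log units; within the scatter), lies within the scatter. The expectation for compound 4 rests on that step and on compound 3 giving 34000 nM. Accordingly the expected step is a 1.1-fold lower number from compound 3 to compound 4 (0.05 log units; within the scatter). Compound 4 is estimated at 30000 nM, between 15000 nM and 60000 nM.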

Compound 4, half-maximal inhibitory concentration: 26000 nM
The estimate for compound 4 lay 1.2-fold (0.06 log units) above the measured number; the range from low to high includes it.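

In this assay, methoxy in place of hydrogen on an aromatic carbon gives a 1.3-fold lower number from compound 3 to compound 4 (0.12 log units; within the scatter), so on this second core the change again produces no step beyond the scatter. The two measured steps agree across the cores: the same change on two cores in this assay, a 1.1-fold lower number (0.05 log units; within the scatter) from compound 1 to compound 2 and a 1.3-fold lower number (0.12 log units; within the scatter) from compound 3 to compound 4, 1.2-fold (0.07 log units) apart, within the scatter of two such steps This supports carrying the change from the core of compound 1 to the core of compound 3 without expecting a shift beyond the scatter, but it rests on two pairs only, and the methoxy sits meta to a large group in compound 4 and at a different place in compound 2, so it does not show the same outcome on other cores or at other places on the ring.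

Still open, from the compounds shown here alone, is whether a different group on that aromatic carbon, such as ethoxy, trifluoromethyl or a carboxylic acid, would give a step beyond the scatter. The compounds shown also leave open whether a second methoxy on the core of compound 3 would behave as the single one does.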